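The compounds below may be only part of what the source reports. "The series", "measured", "known", "first", "only" and "open" are said of these compounds alone.

Working notes on the series. In a functional assay on U-87MG ATCC cells for antiproliferative activity against U-87 MG (Homo sapiens), read by MTT assay, with a stated time of 48 h, tested at 5 uM (a lower number here means a stronger effect, a higher number a weaker effect of the compound at the concentration tested), compound 1 `COc1ccc(-c2nc(C)c(C(=O)CSc3nc(-c4ccc(OC)cc4)c(C#N)c(=O)[nH]3)s2)cc1` gives 97% and compound 2 `COc1ccc(-c2nc(C)c(C(=O)CSc3nc(-c4ccc(OC)c(OC)c4)c(C#N)c(=O)[nH]3)s2)cc1` gives 81.2%. The two differ by hydrogen in place of methoxy on an aromatic carbon, and the step of a number 15.8 percentage points higher from compound 2 to compound 1 (beyond the scatter). Compound 3 `COc1ccc(-c2nc(SCC(=O)c3sc(-c4ccc(Cl)cc4)nc3C)nc(N)c2C#N)cc1` carries a core built differently from that of compound 2; the difference between the two cores is not broken down here. In this assay compound 3 gives 69.7%, the lowest of the three numbers and beyond the scatter from both of the others.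

Compound 4 `Cc1nc(-c2ccc(Cl)cc2)sc1C(=O)CSc1nc(N)c(C#N)c(-c2ccccc2)n1` has not been measured in this assay. It differs from compound 3 by hydrogen in place of methoxy on an aromatic carbon. This is the same kind of change as that from compound 2 to compound 1, but not the same: there the place was ortho to a methoxy group and meta to a large group, here it is para to a large group. Going by the earlier step, the expected step is a number 10.3 percentage points higher from compound 3 to compound 4 (beyond the scatter), a rise of similar direction but taken with caution, since it rests on a single pair, compound 2 to compound 1 with a number 15.8 percentage points higher from compound 2 to compound 1 (beyond the scatter), on a different core. Compound 4 is therefore estimated at 80%, with a range from 62% to 96%.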

Compound 4, a percentage reported as activity, at one concentration (the size of the read-out at that concentration, not a potency): 71.1%
Estimate against measurement, compound 4: 8.9 percentage points above, and the stated range covers the measured number.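

In this assay, the change from 4-methoxyphenyl to phenyl gives a number 1.4 percentage points higher from compound 3 to compound 4 (within the scatter), so on this core the change leaves no readable mark on the number. The same change therefore does not carry over at the same size from the core of compound 2 to the core of compound 3: the same change on two cores in this assay, a number 15.8 percentage points higher (beyond the scatter) from compound 2 to compound 1 and a number 1.4 percentage points higher (within the scatter) from compound 3 to compound 4, 14.4 percentage points apart, beyond the scatter of two such steps

This rests on one pair per core and does not show which feature of the cores goes with the gap, as those cores differ in more than one place and the change does not sit in the same setting in the two pairs.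

Open, from the compounds shown here alone, is how the number would respond on either core to an amine, a carboxylic acid or a longer chain such as ethoxy in place of the methoxy. Also open is which single difference between the cores matters, as the compounds shown include no pair that differs in only one place between them.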